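Three Aryl Variants at the Stability Limit, a Fourth Expected

A few compounds are considered here, and "the series" means these few. Any claim that something is new, unique, unknown or untested is made for them only; others in the source may bear on it.

Compound 1, `N#Cc1ccc(-c2nc(NCCNc3ccc([N+](=O)[O-])c(N)n3)ncc2-c2ncc[nH]2)cc1`, was tested in an ADME assay on microsomes from liver (Rattus norvegicus) for metabolic stability; on this read-out lower numbers stand for a shorter-lived compound and higher numbers for a longer-lived compound. In this assay compound 1 gives > 0.5 h, which is a limit of the assay rather than a number. Its two neighbours also reach only limits. Compound 2, `Nc1nc(NCCNc2ncc(-c3ncc[nH]3)c(-c3ccccc3Cl)n2)ccc1[N+](=O)[O-]`, gives > 0.5 h, a limit. Compound 3, `Nc1nc(NCCNc2ncc(-c3ncc[nH]3)c(-c3cc(F)c(F)cc3F)n2)ccc1[N+](=O)[O-]`, gives > 0.5 h, again a limit. So compound 1 stands at the same limit as every other measured compound, and no value places it above or below them.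

The steps between these three, a step that the two limits leave unreadable from compound 1 to compound 2, a step that the two limits leave unreadable from compound 1 to compound 3 and a step that the two limits leave unreadable from compound 2 to compound 3, therefore cannot be sized. What they share is the limit of > 0.5 h in this assay, at which 3 of the 3 values shown sit.

Compound 4, `Nc1nc(NCCNc2ncc(-c3ncc[nH]3)c(-c3ccc(Cl)cc3F)n2)ccc1[N+](=O)[O-]`, differs from compound 1 in one place: 4-chloro-2-fluorophenyl in place of 4-cyanophenyl on an aromatic carbon. The three measured changes of this aromatic group all left the compound at the limit, so compound 4 is expected to stay there as well, with an expected step that the limit leaves unreadable from compound 1 to compound 4. The estimated half-life for compound 4 is 1 h, within 0.5 h to 2.5 h.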

Compound 4, half-life: > 0.5 h
Compound 4 was reported as a limit; the forecaster's own chance of this, stated with the estimate: 85%; the middle value is on the limit's open side.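

In this assay compound 4 gives > 0.5 h as a limit of the assay, not a number. Among the compounds shown here, no step from compound 1, compound 2 or compound 3 to compound 4 can be read. As far as these compounds go, how long each of these four compounds actually lasts, and whether their aromatic groups separate them at all, stays open.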